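Triazole-Linked Hydroxamate Series: From Pyridyl to Dichlorophenyl

The source may report more compounds than this note shows. Statements on the series, on what has been measured and on what is new or still open speak of the compounds shown alone.

Measured compounds:
compound 1, `O=C(NO)c1ccc(NCc2nc(-c3cccnc3)nn2-c2ccccc2)cc1`, 57.7%
compound 2, `O=C(NO)c1ccc(NCc2nc(-c3ccccc3)nn2-c2ccc(Br)cc2)cc1`, 65.9%
compound 3, `NC(=O)c1ccc(NCc2nc(-c3ccccc3)nn2-c2ccccc2)cc1`, -4.4%

In an assay on Sf9 cells for inhibition of protein deacetylase HDAC6 (Homo sapiens), read by fluorescence, with a stated time of 40 min, tested at 100 nM (a higher number here means more inhibition at the concentration tested (going by the name of the read-out), a lower number less inhibition), compound 1 gives 57.7%, the second highest of the three numbers. Its nearest neighbour is compound 2 at 65.9%, a gap that stays within the usual scatter, so the two cannot be ranked against each other. Compound 3, at -4.4%, lies far below compound 1, beyond the scatter; it differs from compound 1 in more than one place, so no single change can be tied to that drop.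

Compound 4, `O=C(NO)c1ccc(NCc2nc(-c3ccc(Cl)c(Cl)c3)nn2-c2ccccc2)cc1`, has not yet been measured. It arises from compound 1 by one change, (3,4-dichlorophenyl in place of pyridin-3-yl on an aromatic carbon).

Going by the values given here, no measured pair in this set isolates that change. Compound 2, which carries a phenyl group of carbon only at the same place, gives a number within the scatter of compound 1, and that is the closest guide available. Compound 4 is therefore expected to give about 64% in this assay, with a likely range from 45% to 82%. The estimated step of a number 6.3 percentage points higher from compound 1 to compound 4 (within the scatter) is expected to be small and upward, not clearly beyond the scatter.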

Compound 4, a percentage reported as inhibition, at one concentration (the size of the read-out at that concentration, not a potency): 34.5%
Beside the measured number, compound 4's estimate is 29.5 percentage points above it, and the stated range ends above it.
By their numbers in this assay, from the lowest: compound 3; then compound 4; then compounds 1 and 2 (each within the scatter of the next).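

Putting 3,4-dichlorophenyl in place of pyridin-3-yl on this aromatic carbon gives a step of a number 23.2 percentage points lower from compound 1 to compound 4 (beyond the scatter) in this assay. Going by these compounds alone, this is the first change confined to one place in the set, and it shows that the number responds to what this position carries. The response is only partial, as compound 4 still gives 34.5% in this assay. Nothing measured here bears on why the number falls.

The compounds shown leave open whether the fall goes with the two chlorine atoms or with the loss of the ring nitrogen, which a single chlorophenyl on the core of compound 1 could help to separate. They also leave open how this position would respond to a morpholine or to an aminophenyl group.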